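Acetamido for Hydroxy: What to Expect of Compound 4

The compounds below may be only part of what the source reports. "The series", "measured", "known", "first", "only" and "open" are said of these compounds alone.

compound 1 `Oc1ccc(Nc2nccc(-c3ccncc3)n2)cc1`: 3300 nM
compound 2 `Cc1cccc(Nc2nccc(-c3ccc(C)s3)n2)c1`: 1400 nM
compound 3 `Oc1ccc(Nc2nccc(-c3cccnc3)n2)cc1`: 5100 nM

In a functional assay for inhibition, with Homo sapiens as the target (on this read-out lower numbers stand for stronger inhibition and higher numbers for weaker inhibition), compound 1 holds the second highest of the three numbers. Its nearest neighbour is compound 3, reached by a 1.5-fold higher number from compound 1 to compound 3 (0.19 log units; within the scatter), a step within the scatter. Its furthest is compound 2, whose lower number lies beyond the scatter of compound 1.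

Compound 4 `CC(=O)Nc1ccc(Nc2nccc(-c3ccncc3)n2)cc1` differs from compound 1 in one place: acetamido in place of hydroxy on an aromatic carbon. Going by the values given here, no measured step bears on this change; the only step available, a 1.5-fold higher number from compound 1 to compound 3 (0.19 log units; within the scatter), concerns a different group and was itself within the scatter. A step no larger than the scatter is therefore expected, a 1.1-fold higher number from compound 1 to compound 4 (0.03 log units; within the scatter), in no preferred direction. Compound 4 is estimated at 3500 nM, with a range from 1200 nM to 10000 nM.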

Compound 4, half-maximal inhibitory concentration: 5300 nM
The estimate for compound 4 lay 1.5-fold (0.18 log units) below the measured number; the measured number falls inside the stated range.
By their numbers in this assay, from the lowest: compound 2; then compounds 1, 3 and 4 (each within the scatter of the next).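

In this assay, acetamido in place of hydroxy on an aromatic carbon, para to a large group, gives a 1.6-fold higher number from compound 1 to compound 4 (0.21 log units; within the scatter) although the entering group has 4 heavy atoms against 1 for the group that leaves. The earlier compounds shown here offered no step at this position, and this one shows that the larger group keeps the number within the scatter of compound 1. Nothing available bears on the reason for this result.

On these data alone, whether an amine, a carboxylic acid or a longer chain at this position would also stay within the scatter remains open. So does whether acetamido would behave the same way on compound 3.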